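Trading Isobutyl for Hydrogen: Compound 1 to Compound 3

The compounds below may be only part of what the source reports. "The series", "measured", "known", "first", "only" and "open" are said of these compounds alone.

Compound 1 `CC(C)COc1ccc2oc(/C=C/[S+](C)[O-])cc(=O)c2c1` was tested in a functional assay on DLD-1 cells (Homo sapiens) for cytotoxicity, with a stated time of 48 h (a lower number here means a stronger inhibitor, a higher number a weaker inhibitor), where compound 1 gives 5000 nM. Compound 2 `C[S+]([O-])/C=C/c1oc2ccccc2c(=O)c1Cc1ccccc1` gives 5100 nM in this assay; the two numbers lie within the scatter of each other, so neither compound stands apart, and compound 1 simply holds the lowest of the two numbers. Compound 3 `C[S+]([O-])/C=C/c1cc(=O)c2cc(O)ccc2o1` is not yet measured. The change from compound 1 to compound 3 is hydrogen in place of isobutyl on an oxygen on an aromatic ring. For the measured compounds named here, no measured pair shows this change, so its size is unknown. Compound 3 is expected to give 6000 nM, with a range from 2500 nM to 15000 nM, in this assay. The expected step is a 1.2-fold higher number from compound 1 to compound 3 (0.08 log units; within the scatter), hardly beyond the scatter.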

Compound 3, half-maximal inhibitory concentration: > 10000 nM
Compound 3 ended at the assay's limit; the forecaster's own chance of this, stated with the estimate: 10%; middle value at least 1.6-fold (0.22 log units) away from the limit.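

In this assay, compound 3 gives > 10000 nM, which is a limit of the assay and not a number. For the compounds shown here, putting hydrogen in place of isobutyl on this oxygen gives an at least 2.0-fold higher number from compound 1 to compound 3 (0.30 log units; that floor lies within the scatter), the first reading of this change at this position. The step therefore has only a floor, and its upper end stays open: the limit of > 10000 nM in this assay, at which 1 of the 3 values shown sits.

The compounds shown leave open how a methyl, an ethyl or a longer chain on this oxygen would read in this assay. They also leave open whether an amine-bearing chain there would read differently from isobutyl.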